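A few compounds are considered here, and "the series" means these few. Any claim that something is new, unique, unknown or untested is made for them only; others in the source may bear on it.

Measured in an ADME assay on CCRF-HSB-2 cells (Homo sapiens) for cytotoxicity, with a stated time of 7 days; on this read-out lower numbers stand for higher toxicity in this test and higher numbers for lower toxicity in this test:
- compound 1 `C=CCOc1nc(N)nc2c1ncn2/C=C1/CC1(CO)CO`: > 20000 nM
- compound 2 `CCCNc1nc(N)nc2c1ncn2/C=C1/CC1(CO)CO`: > 20000 nM

Compound 2 is known only as a limit, and both measured compounds stand at the limit of > 20000 nM in this assay, at which 2 of the 2 values shown sit. Compound 3 `CCCCCCCCSc1nc(N)nc2c1ncn2/C=C1/CC1(CO)CO` carries octylsulfanyl in place of propylamino on an aromatic carbon. Within the data shown here, the only measured step, a step that the two limits leave unreadable from compound 1 to compound 2, has no readable size and sets no size for this change. A modest estimated an at least 1.3-fold lower number from compound 2 to compound 3 (0.12 log units; that floor lies within the scatter) is expected in this assay, towards higher toxicity if it can be read at all. Compound 3 is estimated at 15000 nM, with an expected range of 4000 nM to 30000 nM.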

Compound 3, half-maximal cytotoxic concentration: 60000 nM
The estimate for compound 3 lay 4.0-fold (0.60 log units) below the measured number; the whole stated range lies below it.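

No step from compound 1 or compound 2 to compound 3 can be read, because both earlier compounds stand at a limit: the limit of > 20000 nM in this assay, at which 2 of the 3 values shown sit.

Still open, as far as these compounds go, is how octylsulfanyl in compound 3 truly compares with allyloxy in compound 1 or propylamino in compound 2.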